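Cytotoxicity notes on compound 1 and a hydroxypropyl analogue

The compounds below may be only part of what the source reports. "The series", "measured", "known", "first", "only" and "open" are said of these compounds alone.

Measured compounds; every value is a limit of the assay, not a number:
Compound 1 `CCCNc1cc(Oc2c(OC)cc3cc(C#N)ccc3c2OC)nc(Nc2ccc(C#N)cc2)n1`: > 125000 nM
Compound 2 `COc1cc2cc(C#N)ccc2c(OC)c1Oc1cc(NC(C)(C)C)nc(Nc2ccc(C#N)cc2)n1`: > 125000 nM
Compound 3 `COc1cc2cc(C#N)ccc2c(OC)c1Oc1cc(NCCCOC(C)C)nc(Nc2ccc(C#N)cc2)n1`: > 125000 nM

In an ADME assay on MT4 cells (Homo sapiens) for cytotoxicity, read by MTT assay, with a stated time of 5 days (a lower number here means that less compound is tolerated, a higher number that more compound is tolerated), compound 1 gives > 125000 nM, a limit. Compound 2 and compound 3 are reported at the same limit: the limit of > 125000 nM in this assay, at which 3 of the 3 values shown sit. Accordingly a step that the two limits leave unreadable from compound 1 to compound 2 and a step that the two limits leave unreadable from compound 1 to compound 3, as is a step that the two limits leave unreadable from compound 2 to compound 3.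

Compound 4 `COc1cc2cc(C#N)ccc2c(OC)c1Oc1cc(NCCCO)nc(Nc2ccc(C#N)cc2)n1` differs from compound 1 by hydroxy in place of hydrogen on a saturated chain carbon, three bonds along the chain from a nitrogen on an aromatic ring. Both measured steps from compound 1 change the group on the same nitrogen on an aromatic ring, and neither yields a readable size, so no direction can be drawn for this assay; the three limits only suggest that such changes leave the read-out at the limit. Compound 4 is therefore expected to show a step that the limit leaves unreadable from compound 1 to compound 4. For compound 4 the estimate in this assay is 200000 nM, between 90000 nM and 450000 nM, most probably reported again as a limit.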

Compound 4, half-maximal cytotoxic concentration: 23500 nM
Beside the measured number, compound 4's estimate is 8.5-fold (0.93 log units) above it; the measured number lies below the stated range.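

In this assay the free hydroxy at the end of the propyl chain brings the first readable cytotoxicity on this nitrogen, with an at least 5.3-fold lower number from compound 1 to compound 4 (0.72 log units; beyond the scatter). Removing the isopropyl from the oxygen gives an at least 5.3-fold lower number from compound 3 to compound 4 (0.72 log units; beyond the scatter), and the change from tert-butyl gives an at least 5.3-fold lower number from compound 2 to compound 4 (0.72 log units; beyond the scatter), so among these compounds lower tolerance goes with the free hydroxy, not with the chain as such. The other compounds stay at the limit, and the steps among them cannot be read: the limit of > 125000 nM in this assay, at which 3 of the 4 values shown sit.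

Still open, on these data alone, is whether an amine or a carboxylic acid at the chain end would lower the number as well. Also open, as far as these compounds go, is whether a longer chain carrying the hydroxy would keep this step.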